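Thiophene replaces bromophenyl on a shared imidazopyrazine-type core

The source may report more compounds than this note shows. Statements on the series, on what has been measured and on what is new or still open speak of the compounds shown alone.

The two measured compounds:
compound 1, `Fc1ccc(-c2cn3ccnc3c(-c3ccc4ncn(C5CCCCC5)c4c3)n2)cc1`, 25.2%;
compound 2, `Brc1ccc(-c2cn3ccnc3c(-c3ccc4ncn(C5CCCCC5)c4c3)n2)cc1`, 20.4%.

Both compounds were tested in a functional assay on MOLT-4 cells (Homo sapiens) for inhibition, read by sulforhodamine B assay, with a stated time of 48 h, tested at 10 uM; a lower number here means less inhibition, a higher number more inhibition at the concentration tested (going by the name of the read-out). Within the data shown here, compound 1 gives 25.2% and compound 2 gives 20.4% in this assay, and the only measured step, a number 4.8 percentage points lower from compound 1 to compound 2 (within the scatter), places the two numbers within the usual scatter of one another, so neither compound can be set above or below the other on what is known. Compound 2 therefore stands level with compound 1.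

The next compound, compound 3, `c1csc(-c2cn3ccnc3c(-c3ccc4ncn(C5CCCCC5)c4c3)n2)c1`, differs from compound 2 in one place: thiophen-2-yl in place of 4-bromophenyl on an aromatic carbon.

Among the measured compounds shown here, only the step from compound 1 to compound 2 bears on this change, and it exchanged one halogen for another on the same phenyl ring, which is a different kind of change from replacing the whole 4-bromophenyl by thiophen-2-yl. That step stayed within the scatter. For the measured compounds named here, since the one step seen on this part of the molecule produced no change beyond the scatter, compound 3 is expected to give a number close to that of compound 2, with a step of a number 1.6 percentage points higher from compound 2 to compound 3 (within the scatter). The estimate for compound 3 in this assay is 22%, with a range from 8% to 38%.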

Compound 3, a percentage reported as inhibition, at one concentration (the size of the read-out at that concentration, not a potency): 30.8%
The estimate for compound 3 lay 8.8 percentage points below the measured number, and the stated range covers the measured number.
By their numbers in this assay, from the lowest: compounds 2, 1 and 3 (each within the scatter of the next, the first and the last beyond it).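

In this assay, among these compounds, replacing 4-bromophenyl with thiophen-2-yl on this aromatic carbon gave a number 10.4 percentage points higher from compound 2 to compound 3 (beyond the scatter) and so produced the first step at this position to pass the scatter, although only modestly. The separation does not extend to the other phenyl compound: replacing 4-fluorophenyl with thiophen-2-yl gave a number 5.6 percentage points higher from compound 1 to compound 3 (within the scatter) and leaves compound 3 level with compound 1, so thiophen-2-yl is set apart only from 4-bromophenyl, not from both phenyl groups. Among the compounds shown here, no measurement is available that would explain why the one exchange passes the scatter and the other does not.

The compounds shown leave open whether an unsubstituted phenyl, a furan-2-yl or a pyridin-3-yl group at this carbon would give a number apart from those of compound 1 and compound 3, and whether an amine or a carboxylic acid carried on such a ring would shift the number at all. They also leave open whether the modest step seen here at a single concentration would carry over to a full concentration-response potency measurement on these cells.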